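A few compounds are considered here, and "the series" means these few. Any claim that something is new, unique, unknown or untested is made for them only; others in the source may bear on it.

Measured so far in a functional assay on DU-145 cells (Homo sapiens) for inhibition, read by trypan blue exclusion, with a stated time of 96 h; on this read-out lower numbers stand for stronger inhibition of growth and higher numbers for weaker inhibition of growth:
compound 1 `O=C(O)c1ccc(C(=O)/C(=C\c2ccc(F)c([N+](=O)[O-])c2)SCc2ccc(Cl)cc2)cc1`, 50000 nM;
compound 2 `CCOc1ccc(/C=C(\C(=O)c2ccc(Cl)cc2)S(=O)(=O)Cc2ccc(F)cc2)cc1OC`, 50000 nM;
compound 3 `O=C(O)c1ccc(C(=O)/C(=C\c2ccc(F)c([N+](=O)[O-])c2)SCc2ccc(F)cc2)cc1`, 1000 nM.

Compound 1 stands level with compound 2 at the digits given, and the two share the highest number of the three; compound 3 lies farthest from it, the step being a 50-fold lower number from compound 1 to compound 3 (1.70 log units; beyond the scatter).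

Compound 4 `O=C(O)c1ccc(C(=O)/C(=C\c2ccc(Cl)c([N+](=O)[O-])c2)SCc2ccc(Cl)cc2)cc1` differs from compound 1 in one place: chloro in place of fluoro on an aromatic carbon. Among the measured compounds shown here, the one measured step, a 50-fold lower number from compound 1 to compound 3 (1.70 log units; beyond the scatter), swaps the same two halogens but at another place, so it bears only loosely on this change. For the measured compounds named here, no step at the changed place is known. Compound 4 is therefore expected to stay near compound 1, with no change at the digits printed from compound 1 to compound 4 (within the scatter) as the estimate and no step beyond the scatter. The estimate for compound 4 is 50000 nM, with a range from 15000 nM to 100000 nM.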

Compound 4, concentration for 50% growth inhibition: 1000 nM
Beside the measured number, compound 4's estimate is 50-fold (1.70 log units) above it, and the stated range ends above it.
By their numbers in this assay, from the lowest: compounds 3 and 4 (each within the scatter of the next); then compounds 1 and 2 (each within the scatter of the next).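

In this assay, the halogen on the aromatic carbon ortho to the nitro group proves no silent place: chloro in place of fluoro there gives a 50-fold lower number from compound 1 to compound 4 (1.70 log units; beyond the scatter). The earlier step, a 50-fold lower number from compound 1 to compound 3 (1.70 log units; beyond the scatter), came from fluoro in place of chloro at another place, so across these two places neither halogen gives the lower number at both. Nothing measured here accounts for either step. The compounds shown leave open whether bromo or an amine at this position would also give a low number, and how chloro here would read with fluoro at the other place.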